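The compounds below may be only part of what the source reports. "The series", "measured", "known", "first", "only" and "open" are said of these compounds alone.

Measured compounds: compound 1 `C/C=C1/[C@H](O[C@@H]2O[C@H](CO)[C@@H](O)[C@H](O)[C@H]2O)OC=C(C(=O)OC)[C@H]1CC(=O)O` with > 15000 nM; compound 2 `C/C=C1/[C@H](O[C@@H]2O[C@H](COC(C)=O)[C@@H](OC(C)=O)[C@H](OC(C)=O)[C@H]2OC(C)=O)OC=C(C(=O)OC)[C@H]1CC(=O)O` with > 15000 nM; compound 3 `C/C=C1/[C@H](O[C@@H]2O[C@H](CO)[C@@H](O)[C@H](O)[C@H]2O)OC=C(C(=O)OC)[C@H]1CC(=O)OC` with > 15000 nM.

The series was tested in a functional assay on SK-BR-3 cells (Homo sapiens) for antiproliferative activity, read by MTT assay, with a stated time of 72 h; on this read-out lower numbers stand for stronger inhibition and higher numbers for weaker inhibition. Compound 1 gave > 15000 nM, which is a limit of the assay and not a number. Compound 2 likewise gave > 15000 nM, again a limit. Compound 3 gave > 15000 nM, also a limit. All three values therefore sit at the limit of > 15000 nM in this assay, at which 3 of the 3 values shown sit, and no difference in potency can be read among them.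

Compound 3 and compound 1 differ by hydrogen in place of methyl on an oxygen next to a carbonyl group. The corresponding step in this assay, a step that the two limits leave unreadable from compound 3 to compound 1, cannot be sized because both ends are limits. Compound 2 and compound 3 have different cores; that difference is not broken down here.

Compound 4 `C/C=C1/[C@H](O[C@@H]2O[C@H](COC(C)=O)[C@@H](OC(C)=O)[C@H](OC(C)=O)[C@H]2OC(C)=O)OC=C(C(=O)O)[C@H]1CC(=O)O` has not yet been measured. It stands to compound 2 as compound 1 stands to compound 3, namely by hydrogen in place of methyl on an oxygen next to a carbonyl group, the same change at the same place. Within the data shown here, since the only measured instance of this change, from compound 3 to compound 1, runs from one limit to another, nothing in the data suggests that it turns an inactive compound into an active one. Compound 4 is therefore expected to remain at the limit as well, with an estimated step that the limit leaves unreadable from compound 2 to compound 4 from compound 2. For compound 4 the estimate in this assay is 30000 nM, with a plausible range from 10000 nM to 100000 nM.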

Compound 4, half-maximal inhibitory concentration: > 20000 nM
Compound 4 ended at the assay's limit; the forecaster's own chance of this, stated with the estimate: 85%; the middle value does not contradict the limit.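

In this assay compound 4 gave > 20000 nM, which is a limit and not a number. Compound 2 gave > 15000 nM, also a limit, so no step can be read between compound 2 and compound 4. The compounds shown leave open whether any member of this series reaches a measurable potency in this assay, and what the change from methoxycarbonyl to carboxy does where a real number exists.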